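The source may hold more compounds than are shown below. What is called first, only, known or untested is meant among the compounds shown, and "the series" means these compounds.

Compound 1 `CC(C)CCN(C)Cc1cn(CC(O)COC(=O)C2CCCCC2)nn1`: 0%
Compound 2 `CCCCN(CCCC)Cc1cn(CC(O)COCc2ccccc2)nn1`: 6%
Compound 3 `CCCCN(CCCC)Cc1cn(CC(O)COC(=O)C2CCCCC2)nn1`: 12%

All three were tested in an assay on nucleic acid for inhibition of Nucleic Acid, read by fluorescence, tested at 100 uM; on this read-out higher numbers stand for more inhibition at the one concentration tested (going by the name of the read-out) and lower numbers for less inhibition. Compound 3 stands highest of the three numbers with 12%. Its gap to compound 2 is within the usual scatter of this assay, so the two cannot be ordered. The other step, a number 12 percentage points higher from compound 1 to compound 3 (beyond the scatter), does lie beyond the scatter and comes from the amine end of the shared core, not from the side chain bearing the oxygen.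

Compound 4 `CCCCC(O)Cn1cc(CN(CCCC)CCCC)nn1` has not been measured. It differs from compound 3 in one place: propyl in place of (cyclohexylcarbonyl)oxy on a saturated chain carbon, two bonds along the chain from an oxygen on a saturated carbon. For the measured compounds named here, the only measured step at this position is a number 6 percentage points higher from compound 2 to compound 3 (within the scatter), which stayed within the scatter even though the group on that oxygen changed considerably. Going by the values given here, nothing measured so far concerns a plain propyl at this place, so the expectation rests on that one step alone. A change of roughly that size, or none beyond the scatter, is therefore expected, with a slight lean downward because the exchange from compound 2 to compound 3 gave a number 6 percentage points higher from compound 2 to compound 3 (within the scatter) and compound 4 moves away from the group that sat at the top. The expected step is a number 4 percentage points lower from compound 3 to compound 4 (within the scatter). Compound 4 is estimated to give 8% in this assay, within a range from -4% to 20%.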

Compound 4, a percentage reported as inhibition, at one concentration (the size of the read-out at that concentration, not a potency): 18%
For compound 4 the middle estimate is 10 percentage points below the measured one; low and high end bracket the measured number.
By their numbers in this assay, from the lowest: compounds 1, 2, 3 and 4 (each within the scatter of the next, the first and the last beyond it).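

In this assay, for the compounds shown here, the earlier compounds changed only the group on the oxygen, whereas compound 4 replaces the whole (cyclohexylcarbonyl)oxy group with a plain propyl, and the result is a number 6 percentage points higher from compound 3 to compound 4 (within the scatter). The six-membered ring and the carbonyl can therefore be removed together without a drop beyond the scatter, so neither is required to keep the number at this level in this assay. Going by these compounds alone, measured against benzyloxy, the same propyl gives a number 12 percentage points higher from compound 2 to compound 4 (beyond the scatter), the first step at this position to clear the scatter, and nothing available explains why the shorter, ring-free group reads this way.

From the compounds shown here alone, all of these comparisons at the position carry the dibutylamino group, so it remains open whether propyl would have the same effect alongside the isopentyl(methyl)amino group of compound 1. Going by these compounds, it is also open how a longer chain such as hexyl, or a carboxylic acid or an amine, would read on this saturated chain carbon, and so whether the read-out follows chain length at all.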